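Furan to cyanophenyl exchange on the shared core

The source may hold more compounds than are shown below. What is called first, only, known or untested is meant among the compounds shown, and "the series" means these compounds.

Working notes on the series. Compound 1 `Nc1nc(-c2ccco2)nc2sc(CN3CCC(F)CC3)cc12` in an assay on CHO-K1 cells for antagonist activity at adenosine receptor A1 (Homo sapiens), read by a beta-galactosidase reporter, with stated times of 15 min and 6 h (a lower number here means a stronger inhibitor, a higher number a weaker inhibitor), gives 740 nM. Compound 2 `C[C@@H]1CCC[C@H](C)N1Cc1cc2c(N)nc(-c3ccc(C(F)F)o3)nc2s1` gives 730 nM in this assay. Compound 3 `Nc1nc(-c2ccc(Br)o2)nc2sc(CN3CCCC3)cc12` gives 710 nM in this assay, the smallest of the three figures, yet its gaps to compound 1 and to compound 2 both lie within the scatter, so the three stand level. Compound 4 `N#Cc1cccc(-c2nc(N)c3cc(CN4CCCC4)sc3n2)c1` is not yet measured; it differs from compound 3 by 3-cyanophenyl in place of 5-bromofuran-2-yl on an aromatic carbon. Within the data shown here, no measured pair shows an exchange of this kind, so the size of the step is open; a move beyond the scatter in either direction is possible, a weakening being judged somewhat more likely than a gain. The step from compound 3 to compound 4 is expected to be a 2.1-fold higher number from compound 3 to compound 4 (0.32 log units; beyond the scatter). Compound 4 is expected to give 1500 nM in this assay, within 300 nM to 7000 nM.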

Compound 4, inhibition constant: 130 nM
The estimate for compound 4 lay 12-fold (1.06 log units) above the measured number, and the stated range ends above it.
By their numbers in this assay, from the lowest: compound 4; then compounds 3, 2 and 1 (each within the scatter of the next).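

In this assay the exchange of 5-bromofuran-2-yl for 3-cyanophenyl on the aromatic carbon between two ring nitrogen atoms gives a 5.5-fold lower number from compound 3 to compound 4 (0.74 log units; beyond the scatter), so this position responds to the group it carries and accepts a six-membered aromatic ring of carbon only. The earlier compounds shown here stood level and differed in more than one place, so they showed nothing of this position alone. No measurement at hand accounts for the step. Among these compounds, the single step does not separate the ring from the nitrile, and a plain phenyl or a 3-methoxyphenyl group would be needed to do so. From the compounds shown here alone, whether the gain holds with an amine other than the pyrrolidine, such as piperidine, remains open.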